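A few compounds are considered here, and "the series" means these few. Any claim that something is new, unique, unknown or untested is made for them only; others in the source may bear on it.

Measured so far in a physicochemical assay for solubility, at pH 7; on this read-out lower numbers stand for lower solubility and higher numbers for higher solubility:
compound 1 `CN1CCC(C(=O)N2Cc3c(NC(=O)Nc4cccc(F)c4)n[nH]c3C2(C)C)CC1` — > 225000 nM
compound 2 `CN1CCC(C(=O)Nc2n[nH]c3c2CN(C(=O)C(C)(C)C)C3(C)C)CC1` — > 225000 nM
compound 3 `CCN1CCC(C(=O)N2Cc3c(NC(=O)c4ccc(F)cc4)n[nH]c3C2(C)C)CC1` — > 225000 nM

Each of the three values above is a limit of this assay and not a number. (the limit of > 225000 nM in this assay, at which 3 of the 3 values shown sit). Compound 2 therefore stands at the limit of this assay, with no number of its own. The two other values shown stand at the same limit, so no order among the three compounds can be read from this assay, and nothing can be said about the size of any step between them.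

Compound 4 `CC(C)(C)C(=O)N1Cc2c(NC(=O)C3CCNCC3)n[nH]c2C1(C)C` is the next structure to be measured in this assay. It differs from compound 2 in one place: hydrogen in place of methyl on an amine nitrogen in a ring.

Going by the values given here, no step between two measured compounds is available in this assay, so the size of the step has to be judged from the change alone. The expectation is for no step beyond the scatter, in either direction; the expected step in this assay is a step that the limit leaves unreadable from compound 2 to compound 4. For compound 4 the estimate in this assay is 300000 nM, with a range from 150000 nM to 600000 nM, and the reading is expected to be a limit again rather than a number.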

Compound 4, solubility: > 225000 nM
Compound 4 gave a limit, no number; the forecaster's own chance of this, stated with the estimate: 80%; the middle value does not contradict the limit.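

In this assay compound 2 and compound 4 each give a limit and not a number, so no step can be read from compound 2 to compound 4 for hydrogen in place of methyl on an amine nitrogen in a ring: the limit of > 225000 nM in this assay, at which 4 of the 4 values shown sit. The compounds shown leave open any order among compound 1, compound 2, compound 3 and compound 4 in this assay, and the size of this change there.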